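From Chloro to Iodo: Expected Shift in Calpain-1 Inhibition

A few compounds are considered here, and "the series" means these few. Any claim that something is new, unique, unknown or untested is made for them only; others in the source may bear on it.

Compound 1 `O=C(O)/C(S)=C/c1ccccc1Cl`: 20700 nM
Compound 2 `O=C(O)/C(S)=C/c1c[nH]c2cccc(Br)c12`: 100 nM

In an assay on isolated protein for inhibition of Calpain-1 catalytic subunit (Sus scrofa) (on this read-out higher numbers stand for weaker inhibition and lower numbers for stronger inhibition), compound 1 gives 20700 nM, the highest of the two numbers shown; compound 2 gives 100 nM, and the gap between these two values lies beyond the scatter. Compound 3 `O=C(O)/C(S)=C/c1ccccc1I` differs from compound 1 by iodo in place of chloro on an aromatic carbon. Within the data shown here, no measured pair shows such a change here, so any expectation rests on the change itself. With one halogen replaced by another at the same aromatic carbon, the step from compound 1 to compound 3 is expected to be small, at most a modest move towards stronger inhibition, if beyond the scatter at all; that expected step is a 1.4-fold lower number from compound 1 to compound 3 (0.14 log units; within the scatter). Compound 3 is thus estimated at 15000 nM, with a range from 5000 nM to 45000 nM.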

Compound 3, half-maximal inhibitory concentration: 42800 nM
Compound 3: middle estimate off by 2.9-fold (0.46 log units), on the low side, and the stated range covers the measured number.
By their numbers in this assay, from the lowest: compound 2; then compound 1; then compound 3.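

In this assay, iodo in place of chloro gives a 2.1-fold higher number from compound 1 to compound 3 (0.32 log units; beyond the scatter) and so moves the read-out towards weaker inhibition, beyond the scatter. Among these compounds, this aromatic carbon, ortho to a group of 6 heavy atoms, therefore does not treat these two halogens alike, which the earlier compounds could not show. Nothing measured here explains the step.

The compounds shown leave open how fluoro, or a group other than a halogen such as an amine or methoxy, would fare at this carbon.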